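Amide aryl substituent change on the shared core

This account rests on a few compounds, and the source may have more. Where it says the series, first, only, none or still open, it means among the compounds named here.

Measured so far:
compound 1 `O=C(Nc1cccc(-c2oc3cc(-c4ccc(F)cc4)ccc3c(=O)c2O)c1)c1cc(F)cc(F)c1` gives 2070 nM
compound 2 `N#Cc1ccc(C(=O)Nc2cccc(-c3oc4cc(-c5ccc(F)cc5)ccc4c(=O)c3O)c2)cc1` gives 2990 nM

Going by the values given here, in a functional assay on HCC1937 cells (Homo sapiens) for antiproliferative activity, read by CCK-8 assay, with a stated time of 72 h (a higher number here means a weaker inhibitor, a lower number a stronger inhibitor), compound 2 holds the highest of the two numbers, and its only neighbour sits one step away: a 1.4-fold higher number from compound 1 to compound 2 (0.16 log units; within the scatter), within the scatter. Compound 3 `CCCc1ccc(C(=O)Nc2cccc(-c3oc4cc(-c5ccc(F)cc5)ccc4c(=O)c3O)c2)cc1` is not yet measured; it differs from compound 2 by propyl in place of cyano on an aromatic carbon. Among the compounds with values here, the single measured step touches the same ring position but swaps two other groups, so nothing measured speaks directly to propyl. No step beyond the scatter is expected in this assay, a 1.2-fold lower number from compound 2 to compound 3 (0.08 log units; within the scatter). Compound 3 is therefore estimated at 2500 nM, between 900 nM and 7000 nM.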

Compound 3, half-maximal inhibitory concentration: 15400 nM
The estimate for compound 3 lay 6.2-fold (0.79 log units) below the measured number; the whole stated range lies below it.
By their numbers in this assay, from the lowest: compounds 1 and 2 (each within the scatter of the next); then compound 3.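

In this assay, going by these compounds alone, this position does not tolerate every substituent: propyl in place of cyano gives a 5.2-fold higher number from compound 2 to compound 3 (0.71 log units; beyond the scatter) and is the first step beyond the scatter. The change from 4-propylphenyl in place of 3,5-difluorophenyl gives a 7.4-fold higher number from compound 1 to compound 3 (0.87 log units; beyond the scatter) and sets compound 3 apart from both earlier compounds. Nothing available bears on why the number rises.

As far as these compounds go, whether the step follows the propyl chain itself or the loss of the nitrile remains open. Methyl, a longer chain such as butyl, or an amine at this position would help separate the two.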